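Propyl to 2-methoxyethoxy: working notes on the series

This account rests on a few compounds, and the source may have more. Where it says the series, first, only, none or still open, it means among the compounds named here.

Compound 1 `CC/C=C\C[C@H]1C(=O)C=C[C@H]1CC(=O)OCCCCC`: 25000 nM
Compound 2 `CC/C=C\C[C@H]1C(=O)C=C[C@H]1CC(=O)OCCOCCOCCO`: 42000 nM

Both values come from a functional assay on RAW264.7 cells (Mus musculus) for inhibition, read by ELISA, with a stated time of 24 h; a lower number here means that less compound is needed, a higher number that more compound is needed for the effect. For the measured compounds named here, compound 1 stands within the scatter of compound 2, the only other measured compound, so the two numbers give no order within this pair.

The next compound for this assay is compound 3 `CC/C=C\C[C@H]1C(=O)C=C[C@H]1CC(=O)OCCOCCOC`, which is not yet measured. Its difference from compound 1 is 2-methoxyethoxy in place of propyl on a saturated chain carbon, two bonds along the chain from an oxygen next to a carbonyl group. The change lies on a saturated chain carbon, two bonds along the chain from an oxygen next to a carbonyl group.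

Going by the values given here, only one measured step bears on this. Compound 2 carries 2-(2-hydroxyethoxy)ethoxy in place of propyl at the same place, and that change gave a 1.7-fold higher number from compound 1 to compound 2 (0.23 log units; within the scatter). The group in compound 3 is a different one, so this single step is limited evidence. On that evidence, no step beyond the scatter is expected in this assay, and no firm direction can be assigned.

The estimated value for compound 3 is 32000 nM, with an expected range of 15000 nM to 65000 nM. This estimate means an expected 1.3-fold higher number from compound 1 to compound 3 (0.11 log units; within the scatter).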

Compound 3, half-maximal effective concentration: 33000 nM
The estimate for compound 3 lay 1.0-fold (0.01 log units) below the measured number; the measured number falls inside the stated range.
By their numbers in this assay, from the lowest: compounds 1, 3 and 2 (each within the scatter of the next).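

In this assay, 2-methoxyethoxy on a saturated chain carbon, two bonds along the chain from an oxygen next to a carbonyl group, gives a 1.3-fold higher number from compound 1 to compound 3 (0.12 log units; within the scatter) and so adds a second group at this position that stays within the scatter of propyl. For the compounds shown here, the new pair also gives a first reading of a change further out on the chain: hydrogen in place of hydroxymethyl on a saturated chain carbon bound to an oxygen on a saturated carbon gives a 1.3-fold lower number from compound 2 to compound 3 (0.10 log units; within the scatter) and likewise sets no order between these two compounds. No measurement of any other kind is available to account for these three numbers lying within the scatter of one another.

Still open, from the compounds shown here alone, is whether any group at this position can produce a step beyond the scatter, for example an amine, a carboxylic acid or a much longer alkyl chain in place of propyl. Going by these compounds, all three compounds share the same core and the same ester link, so the effect of replacing that ester with an amide also remains unknown.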